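Aryl variation on the fused core: toward a cyanophenyl analogue

The source may hold more compounds than are shown below. What is called first, only, known or untested is meant among the compounds shown, and "the series" means these compounds.

The shared core of compound 1 `COc1ccc(S(=O)(=O)N2CCc3cccc(-c4ccc(F)c(F)c4)c32)cc1` carries a 3,4-difluorophenyl group. Among the measured compounds shown here, in a functional assay on MKN-45 cells (Homo sapiens) for inhibition, with a stated time of 72 h (on this read-out higher numbers stand for weaker inhibition and lower numbers for stronger inhibition), compound 1 gives 55.5 nM, the lowest of the three numbers so far, and both other compounds lie beyond the scatter of it. Compound 2 `COc1ccc(S(=O)(=O)N2CCc3cccc(-c4cc(OC)c(OC)c(OC)c4)c32)cc1` gives 1080 nM in this assay, and compound 3 `COc1ccc(S(=O)(=O)N2CCc3cccc(-c4c(F)c(F)c(F)c(F)c4F)c32)cc1` gives 1780 nM in this assay. For the measured compounds named here, no step between any two of these measured compounds is defined, so only the values themselves are set side by side.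

Compound 4 `COc1ccc(S(=O)(=O)N2CCc3cccc(-c4ccc(C#N)cc4)c32)cc1` is not yet measured. It differs from compound 1 at one place: 4-cyanophenyl in place of 3,4-difluorophenyl on an aromatic carbon. Going by the values given here, the measured set holds no example of a 4-cyanophenyl group at this position. Some weakening is expected because compound 2 at 1080 nM and compound 3 at 1780 nM both sit above compound 1. The step from compound 1 to compound 4 in this assay is expected to be modest, on the order of a 2.9-fold higher number from compound 1 to compound 4 (0.46 log units; beyond the scatter). Compound 4 is estimated at 160 nM in this assay, with a range of 40 nM to 650 nM.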

Compound 4, half-maximal inhibitory concentration: 17.2 nM
Beside the measured number, compound 4's estimate is 9.3-fold (0.97 log units) above it; the measured number lies below the stated range.
By their numbers in this assay, from the lowest: compound 4; then compound 1; then compounds 2 and 3 (each within the scatter of the next).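

In this assay, 4-cyanophenyl in place of 3,4-difluorophenyl on this aromatic carbon gives a 3.2-fold lower number from compound 1 to compound 4 (0.51 log units; beyond the scatter), so the position can take a non-fluorinated aryl group and still move to a lower number. The swap keeps the heavy-atom count and the single six-membered aromatic ring, while bringing in a nitrile with one hydrogen-bond acceptor where the leaving group has none, so a change in the substituent alone is enough to produce a step beyond the scatter. Nothing at hand links this step to any measured property of either group.

On these data alone, whether the step follows from gaining the nitrile or from losing the two fluorines stays open, and an unsubstituted phenyl at this position would help separate the two. As far as these compounds go, how a phenyl bearing an amine or a carboxylic acid would read here also remains unknown.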